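The source may report more compounds than this note shows. Statements on the series, on what has been measured and on what is new or still open speak of the compounds shown alone.

Compounds measured so far:
compound 1: `Cc1c(C(=O)N/N=C\c2cc(O)ccc2O)oc2cccc(O)c12`
compound 2: `Cc1c(C(=O)N/N=C\c2ccc(O)c(O)c2O)oc2cccc(O)c12`

In a functional assay on PC-3 cells (Homo sapiens) for inhibition (a higher number here means a weaker inhibitor, a lower number a stronger inhibitor), compound 1 gives 95500 nM. For compound 2 this assay reports only a limit and no number, >= 40000 nM; that limit is the limit of >= 40000 nM in this assay, at which 1 of the 2 values shown sits. Within the data shown here, compound 1 thus stands as the only plain number among the values shown, and it marks a weak inhibitor. Among the measured compounds shown here, since no two measured compounds differ in just one place, no measured step exists to lean on, and the two values together show only that both compounds are weak.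

Compound 3, `Cc1c(C(=O)N/N=C\c2cccc(Br)c2O)oc2cccc(O)c12`, has not been measured yet. It differs from compound 1 in one place: 3-bromo-2-hydroxyphenyl in place of 2,5-dihydroxyphenyl on a carbon with a double bond to nitrogen. The rest of the molecule is unchanged.

Without a measured step, the expected change is small: the step of a 1.6-fold lower number from compound 1 to compound 3 (0.20 log units; within the scatter) is expected to be no larger than the usual scatter, or only modestly beyond it, with no clear direction to lean on. In this assay compound 3 is therefore expected near 60000 nM, within 15000 nM to 200000 nM.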

Compound 3, half-maximal inhibitory concentration: 16600 nM
For compound 3 the middle estimate is 3.6-fold (0.56 log units) above the measured one, within the range that was stated.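

Among these compounds, replacing 2,5-dihydroxyphenyl with 3-bromo-2-hydroxyphenyl on a carbon with a double bond to nitrogen gives a 5.8-fold lower number from compound 1 to compound 3 (0.76 log units; beyond the scatter), the first measured step in this assay. It shows that the number in this assay responds to a change at this place, which the two earlier compounds could not show, though the step is modest and compound 3 at 16600 nM is still a weak inhibitor. Among the compounds shown here, nothing measured so far accounts for the size or direction of this step.

The swap makes two changes to the ring at once, with one hydroxyl leaving and a bromine entering, so the compounds shown leave open which of the two carries the step, or whether both are needed. As far as these compounds go, it also remains open whether another group in the place of the bromine, such as a chlorine, a methoxy group or an amine, would keep the step, enlarge it or lose it.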